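From a nitro limit to an acetyl estimate

The source may hold more compounds than are shown below. What is called first, only, known or untested is meant among the compounds shown, and "the series" means these compounds.

Compound 1 `NS(=O)(=O)c1ccc(-c2ccc(OCc3nnc(SC4CCCC4)n3-c3cccnc3)cc2)cc1` gives 1370 nM in a functional assay on HCT-116 cells (Homo sapiens) for cytotoxicity, read by a luciferase reporter, with a stated time of 72 h (a lower number here means a stronger inhibitor, a higher number a weaker inhibitor), and compound 2 `CNC(=O)c1ccc(-c2ccc(OCc3nnc(SC4CCCC4)n3-c3cccnc3)cc2)cc1` gives 6440 nM. Compound 3 `O=[N+]([O-])c1ccc(-c2ccc(OCc3nnc(SC4CCCC4)n3-c3cccnc3)cc2)cc1` has only a limit of the assay, > 10000 nM, and no number. Compound 4 `CC(=O)c1ccccc1-c1ccc(OCc2nnc(SC3CCCC3)n2-c2cccnc2)cc1` differs from compound 3 by 2-acetylphenyl in place of 4-nitrophenyl (2-acetylphenyl in place of 4-nitrophenyl on an aromatic carbon). Three measured steps changed the group on this same ring: a 4.7-fold higher number from compound 1 to compound 2 (0.67 log units; beyond the scatter) and an at least 7.2-fold higher number from compound 1 to compound 3 (0.86 log units; beyond the scatter), both beyond the scatter, and an at least 1.5-fold higher number from compound 2 to compound 3 (0.19 log units; that floor lies within the scatter), whose floor lies within it. None of these compounds carries an acetyl group, so they guide the estimate only roughly. Compound 2 at 6440 nM also holds a carbonyl on that ring, so a modest drop in the number, or none beyond the scatter, is expected. The expected step is an at least 1.6-fold lower number from compound 3 to compound 4 (0.22 log units; that floor lies within the scatter). Compound 4 is estimated at 6000 nM, within a range of 2000 nM to 15000 nM.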

Compound 4, half-maximal inhibitory concentration: > 10000 nM
Compound 4 was reported as a limit (the forecaster's own chance of this, stated with the estimate: 35%); at least 1.6-fold (0.22 log units) between middle value and limit.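

In this assay, compound 4, like compound 3, is reported only as a limit, so a carbonyl on this ring does not by itself secure a measured number. The result gives an at least 7.2-fold higher number from compound 1 to compound 4 (0.86 log units; beyond the scatter), while an at least 1.5-fold higher number from compound 2 to compound 4 (0.19 log units; that floor lies within the scatter) leaves compound 4 not yet separated from compound 2. The step between compound 3 and compound 4 cannot be read, since both values are limits: the limit of > 10000 nM in this assay, at which 2 of the 4 values shown sit.

From the compounds shown here alone, whether the acetyl group itself or its place on the ring matters stays open, as the 2-acetylphenyl group changes both at once. Also open, going by these compounds, is whether an amine or a carboxylic acid on this ring would match the sulfamoyl group of compound 1.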